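Adding a Methyl Group: From Compound 2 to Compound 3

The source may report more compounds than this note shows. Statements on the series, on what has been measured and on what is new or still open speak of the compounds shown alone.

Compound 1 `Cc1ccnc(/C(N)=N/NC(=S)N2CCSCC2)c1`: 34.6%
Compound 2 `N/C(=N\NC(=S)N1CCCC1)c1ccccn1`: 39.8%

Both were tested in a functional assay on A-431 cells (Homo sapiens) for cytotoxicity, read by MTT assay, with a stated time of 72 h, tested at 1 uM; on this read-out lower numbers stand for less inhibition of growth and higher numbers for more inhibition of growth at the one concentration tested. There compound 2 and compound 1 give numbers that lie within the usual scatter of each other, so neither can be set above the other. Compound 3 `Cc1ccnc(/C(N)=N/NC(=S)N2CCCC2)c1` is not yet measured; it differs from compound 2 by methyl in place of hydrogen on an aromatic carbon. Among the measured compounds shown here, no measured pair differs only in this way, so the size of the step is unknown; compound 1 carries the same methyl but also differs elsewhere, and its number sits close to that of compound 2. The step is therefore expected to stay within the scatter, a number 1.8 percentage points lower from compound 2 to compound 3 (within the scatter). Compound 3 is estimated at 38%, between 25% and 52%.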

Compound 3, percent growth inhibition at one concentration: 58.5%
Estimate against measurement, compound 3: 20.5 percentage points below; the whole stated range lies below it.
By their numbers in this assay, from the lowest: compounds 1 and 2 (each within the scatter of the next); then compound 3.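

In this assay, among the compounds shown here, methyl in place of hydrogen on the aromatic carbon opposite the ring nitrogen gives a first reading for this position, with a number 18.7 percentage points higher from compound 2 to compound 3 (beyond the scatter). With that methyl present on both compounds, the group on the thiocarbonyl carbon also matters: pyrrolidin-1-yl in place of thiomorpholin-4-yl gives a number 23.9 percentage points higher from compound 1 to compound 3 (beyond the scatter) and so both places affect this read-out. Nothing measured here explains either step.

From the compounds shown here alone, whether an ethyl, a methoxy or a chlorine on that aromatic carbon would match methyl remains open. So does the size of the methyl step when thiomorpholin-4-yl sits on the thiocarbonyl carbon.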